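A few compounds are considered here, and "the series" means these few. Any claim that something is new, unique, unknown or untested is made for them only; others in the source may bear on it.

Of the compounds shown here, three built on one shared core have been measured in a functional assay on cells for agonist activity at Free fatty acid receptor 1 (Mus musculus), read by FLIPR and calcium flux, with a stated time of 100 s; a lower number here means that less compound is needed, a higher number that more compound is needed for the effect. Compound 1 `Cc1ccccc1COc1ccc(N2CCC[C@H]2CC(=O)O)cc1` gives 3400 nM, compound 2 `Cc1ccccc1Oc1ccc(N2CCC[C@H]2CC(=O)O)cc1` gives 5600 nM, and compound 3 `O=C(O)C[C@@H]1CCCN1c1ccc(Oc2ccc(Cl)cc2Cl)cc1` gives 3200 nM, the lowest of the three numbers, although each step between them stays within the scatter: a 1.6-fold higher number from compound 1 to compound 2 (0.22 log units; within the scatter), a 1.1-fold lower number from compound 1 to compound 3 (0.03 log units; within the scatter) and a 1.8-fold lower number from compound 2 to compound 3 (0.24 log units; within the scatter). Compound 4 `O=C(O)C[C@@H]1CCCN1c1ccc(Oc2ccccc2F)cc1` differs from compound 3 in that (2-fluorophenyl in place of 2,4-dichlorophenyl on an oxygen on an aromatic ring). The step that bears most on this exchange is a 1.8-fold lower number from compound 2 to compound 3 (0.24 log units; within the scatter), where one ring on that oxygen replaced another and the number barely moved. A similarly small shift in this assay is therefore expected, if anything toward a slightly higher number. Compound 4 is expected to give 5000 nM, with a range from 2000 nM to 12000 nM, which means an estimated step of a 1.6-fold higher number from compound 3 to compound 4 (0.19 log units; within the scatter).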

Compound 4, half-maximal effective concentration: 6900 nM
Beside the measured number, compound 4's estimate is 1.4-fold (0.14 log units) below it; the measured number falls inside the stated range.
By their numbers in this assay, from the lowest: compounds 3, 1, 2 and 4 (each within the scatter of the next, the first and the last beyond it).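

Within the data shown here, this is the first exchange of groups on this oxygen to go beyond the scatter, with a 2.2-fold higher number from compound 3 to compound 4 (0.33 log units; beyond the scatter) when 2-fluorophenyl replaces 2,4-dichlorophenyl. Replacing 2-methylbenzyl with 2-fluorophenyl also goes beyond it, with a 2.0-fold higher number from compound 1 to compound 4 (0.31 log units; beyond the scatter), whereas fluoro in place of methyl on the aromatic carbon gives a 1.2-fold higher number from compound 2 to compound 4 (0.09 log units; within the scatter) and leaves those two compounds indistinguishable. No measurement here gives a reason for these steps. Still open, going by these compounds, is which difference between 2,4-dichlorophenyl and 2-fluorophenyl matters, since the two groups differ in both halogen and number of halogen atoms. On these data alone, it is also open how a ring carrying an amine or a nitrile would behave on this oxygen.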